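A few compounds are considered here, and "the series" means these few. Any claim that something is new, unique, unknown or untested is made for them only; others in the source may bear on it.

Working notes on the series.

Compound 1 `ClCc1ccc(Cn2cnc3c(Cl)ncnc32)cc1` gives 1580 nM in a functional assay on NCI-H226 cells (Homo sapiens) for cytotoxicity, read by sulforhodamine B assay, with a stated time of 48 h; on this read-out lower numbers stand for stronger inhibition of growth and higher numbers for weaker inhibition of growth. Among the measured compounds shown here, compound 2 `Nc1nc(Cl)c2ncn(Cc3ccc(CCl)cc3)c2n1` carries the change amino in place of hydrogen on an aromatic carbon and gives 10200 nM in this assay; the step of a 6.5-fold higher number from compound 1 to compound 2 (0.81 log units; beyond the scatter) is the only paired comparison in hand. Compound 3 `ClCc1ccccc1Cn1cnc2c(Cl)ncnc21` gives 4570 nM in this assay; its number sits between those of compound 1 and compound 2, and the difference between the cores of compound 3 and compound 1 is not broken down here. Compound 4 `Nc1nc(Cl)c2ncn(Cc3ccccc3CCl)c2n1` carries the change (amino in place of hydrogen on an aromatic carbon), the same change as that from compound 1 to compound 2, at the same place. In this assay this change is expected to run in the same direction as a 6.5-fold higher number from compound 1 to compound 2 (0.81 log units; beyond the scatter), of similar size, because only a 6.5-fold higher number from compound 1 to compound 2 (0.81 log units; beyond the scatter) speaks to this change. Compound 4 is therefore expected at about 20000 nM, estimated within 7000 nM to 50000 nM, a step of a 4.4-fold higher number from compound 3 to compound 4 (0.64 log units; beyond the scatter).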

Compound 4, concentration for 50% growth inhibition: 2630 nM
Compound 4: the middle estimate sits 7.6-fold (0.88 log units) above what was measured; measured number outside the range, below it.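

In this assay, amino in place of hydrogen on an aromatic carbon gives a 1.7-fold lower number from compound 3 to compound 4 (0.24 log units; within the scatter), so no effect of the change can be read on the core of compound 3. The change does not carry over in size from the core of compound 1 to the core of compound 3: the same change on two cores in this assay, a 6.5-fold higher number (0.81 log units; beyond the scatter) from compound 1 to compound 2 and a 1.7-fold lower number (0.24 log units; within the scatter) from compound 3 to compound 4, 11-fold (1.05 log units) apart, beyond the scatter of two such steps. A step read on one core is therefore a poor guide to the other in this series, but these two pairs do not show why the steps differ or how the change would run on a further core.

Still open, from the compounds shown here alone, is whether a methylamino or hydroxyl group on the same aromatic carbon, between two ring nitrogen atoms, would follow the amino group on either core.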